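Testing the Mirror Image of Compound 2

This account rests on a few compounds, and the source may have more. Where it says the series, first, only, none or still open, it means among the compounds named here.

Of the compounds shown here, two built on a shared core have been measured so far. In a functional assay on HCT-116 cells (Homo sapiens) for inhibition, read by MTT assay, with a stated time of 72 h (on this read-out lower numbers stand for stronger inhibition and higher numbers for weaker inhibition), compound 2 (`CC1=NN(c2ccccc2)C(=O)[C@@]12C(=O)C=CC[C@H]2c1ccccc1`) gives 4400 nM and compound 1 (`CC1=NN(c2ccccc2)C(=O)[C@]12C(=O)C=CC[C@@H]2c1ccc(C)cc1`) gives 5800 nM. These two values lie within the scatter of each other, so compound 2 stands level with compound 1 on this evidence.

The next compound, compound 3 (`CC1=NN(c2ccccc2)C(=O)[C@]12C(=O)C=CC[C@@H]2c1ccccc1`), relates to compound 2 in an unusual way: the two compounds have the same atoms and bonds and differ only in configuration as drawn: 2 of 2 stereo elements differ (all stereocentres are inverted: mirror images); a stereocentre at a saturated ring carbon is drawn R in compound 2 and S in compound 3; a stereocentre at a saturated ring carbon is drawn S in compound 2 and R in compound 3. Among the compounds with values here, nothing is added or removed, and the only change lies in the spatial arrangement at the two stereocentres. Such a pair can give matching numbers in a cell test, or clearly different ones.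

Compound 1 and compound 2 are not mirror images, so the data hold no direct guide to a step of this kind. The expected change, a 1.3-fold higher number from compound 2 to compound 3 (0.10 log units; within the scatter), is none beyond the scatter in this assay, although a real gap in either direction remains possible. For compound 3 the estimated value is 5500 nM, with an expected range from 2000 nM to 16000 nM.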

Compound 3, half-maximal inhibitory concentration: 6040 nM
Compound 3: the middle estimate sits 1.1-fold (0.04 log units) below what was measured; low and high end bracket the measured number.
By their numbers in this assay, from the lowest: compounds 2, 1 and 3 (each within the scatter of the next).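

In this assay, inverting both stereocentres gives a 1.4-fold higher number from compound 2 to compound 3 (0.14 log units; within the scatter), so this mirror-image pair stands level and the test does not tell the two forms apart. Within the data shown here, the pair gives the first direct look at handedness, and on this one read-out, the drawn configuration of the shared core makes no difference that can be told from the usual scatter. Among these compounds, the other new comparison isolates the methyl group for the first time, and hydrogen in its place on the aromatic carbon gives a 1.0-fold higher number from compound 1 to compound 3 (0.02 log units; within the scatter), so this small swap also leaves the number within the scatter. The reading of the first comparison as a test of configuration alone rests on a single fact: the fact that compounds 2 and 3 differ only in the configuration as drawn.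

As far as these compounds go, what remains open is whether a different group on that aromatic carbon, such as a methoxy group, an amine or a carboxylic acid, would move the number beyond the scatter. The compounds shown also leave open whether the two mirror forms would stay level in a different test, and they cannot tell why this pair matches here.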